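This account rests on a few compounds, and the source may have more. Where it says the series, first, only, none or still open, it means among the compounds named here.

Measured compounds:
Compound 1 `COC(=O)[C@@]1(C)CCC=C2[C@@H]1CC[C@@H](C)[C@]2(C)Cc1c(C)[nH]c2ccccc12` gives 15000 nM in a functional assay on A549 cells (Homo sapiens) for inhibition, read by sulforhodamine B assay, with a stated time of 48 h; on this read-out higher numbers stand for weaker inhibition of growth and lower numbers for stronger inhibition of growth.
Compound 2 `COC(=O)[C@@]1(C)CCC=C2[C@@H]1CC[C@@H](C)[C@]2(C)Cc1c(C)[nH]c2ccc(F)cc12` gives 15000 nM in this assay.

Among the measured compounds shown here, on these numbers compound 2 stands level with compound 1: the step from compound 1 to compound 2 was no change at the digits printed from compound 1 to compound 2 (within the scatter), which covers the one change made so far at that position of the shared core. Compound 3 `COC(=O)[C@@]1(C)CCC=C2[C@@H]1CC[C@@H](C)[C@]2(C)Cc1c(C)[nH]c2ccc(OC)cc12` is the next variation at the same place; the change is methoxy in place of fluoro on an aromatic carbon. For the measured compounds named here, the only measured step that bears on this site is the one from compound 1 to compound 2, and it showed nothing beyond the scatter, so there is no sign that this position moves growth inhibition much, though a methoxy group has not been tried there. The step from compound 2 to compound 3 in this assay is therefore expected to be no change at the digits printed from compound 2 to compound 3 (within the scatter). Compound 3 is expected to give about 15000 nM, in the range 6000 nM to 40000 nM.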

Compound 3, concentration for 50% growth inhibition: 16000 nM
Estimate against measurement, compound 3: 1.1-fold (0.03 log units) below; low and high end bracket the measured number.
By their numbers in this assay, from the lowest: compounds 1, 2 and 3 (each within the scatter of the next).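

In this assay, among the compounds shown here, the position had so far been tested only with fluoro, a single atom. Methoxy is larger, with two heavy atoms and a hydrogen-bond acceptor, yet methoxy in place of fluoro gives a 1.1-fold higher number from compound 2 to compound 3 (0.03 log units; within the scatter), and methoxy in place of hydrogen gives a 1.1-fold higher number from compound 1 to compound 3 (0.03 log units; within the scatter). Hydrogen, fluoro and methoxy at this aromatic carbon therefore cannot be told apart in this read-out, and nothing shown here gives a measured reason for that.

The compounds shown leave open whether an amine, a carboxylic acid or a longer alkoxy chain at this position would shift growth inhibition beyond the scatter. They also leave open whether changes elsewhere on the shared core, such as a carboxylic acid in place of the methyl ester, would matter more.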